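The compounds below may be only part of what the source reports. "The series", "measured", "known", "first", "only" and "open" are said of these compounds alone.

Working notes on the series, read in a functional assay on SK-MEL-147 cells (Homo sapiens) for cytotoxicity, read by MTT assay, with a stated time of 24 h; a lower number here means that less compound is needed, a higher number that more compound is needed for the effect. Compound 1 (`CCOC(=O)c1cc([Se]c2ccc(F)cc2)c2cc(OC)ccc2n1`) gives > 150000 nM, which is a limit of the assay and not a number. Within the data shown here, compound 2 (`COc1ccc([Se]c2cc(-c3ccc(O)cc3)nc3ccc(OC)cc23)cc1`) gives 59200 nM, the only actual number in hand, so it has no measured neighbour to be ranked against.

Compound 3 (`CCOC(=O)c1cc([Se]c2ccc(OC)cc2)c2cc(OC)ccc2n1`) is still unmeasured in this assay. Going to it from compound 2, the change is ethoxycarbonyl in place of 4-hydroxyphenyl on an aromatic carbon; ethoxycarbonyl takes the place of 4-hydroxyphenyl on an aromatic carbon next to the ring nitrogen. Among the measured compounds shown here, no step between measured compounds is available to size this change, so the expectation rests on very little. Compound 1 also carries ethoxycarbonyl and stands at > 150000 nM, again only a limit. On that basis, a move towards more compound being needed for the effect is expected, of moderate size and possibly reaching the limit of the assay. The expected step is a 2.2-fold higher number from compound 2 to compound 3 (0.34 log units; beyond the scatter). For compound 3 the estimated value is 130000 nM. The expected range for compound 3 runs from 55000 nM to 300000 nM.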

Compound 3, half-maximal effective concentration: >= 54300 nM
Compound 3 ended at the assay's limit; the forecaster's own chance of this, stated with the estimate: 50%; the middle value does not contradict the limit.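

Compound 3 gives >= 54300 nM, which is a limit of the assay and not a number, so neither the step from compound 2 to compound 3 nor the step from compound 1, itself only a limit, to compound 3 can be read. The compounds shown leave open how much ethoxycarbonyl in place of 4-hydroxyphenyl, or methoxy in place of fluoro, changes the number.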